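Extending a Methyl to Ethyl on the Shared Core

The source may report more compounds than this note shows. Statements on the series, on what has been measured and on what is new or still open speak of the compounds shown alone.

Measured so far:
compound 1, `Nc1nc(N)c2nc(CCc3ccc(C(=O)NC(CCC(=O)O)C(=O)O)c4ccccc34)cnc2n1`, 1.1 nM
compound 2, `Cc1c(CCc2ccc(C(=O)NC(CCC(=O)O)C(=O)O)c3ccccc23)cnc2nc(N)nc(N)c12`, 9.4 nM

In a functional assay on HL-60 cells (Homo sapiens) for inhibition (on this read-out lower numbers stand for stronger inhibition and higher numbers for weaker inhibition), compound 1 gives 1.1 nM, and in this assay compound 2 gives 9.4 nM. Of the two numbers, compound 2 stands at the higher one, so it is the weaker inhibitor of the pair; the gap to compound 1 lies beyond the scatter of repeated measurements.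

The next compound, compound 3, has the structure `CCc1c(CCc2ccc(C(=O)NC(CCC(=O)O)C(=O)O)c3ccccc23)cnc2nc(N)nc(N)c12`. It differs from compound 2 in one place: methyl in place of hydrogen on a saturated chain carbon bound to an aromatic carbon. Seen one bond further out, the change is methyl to ethyl on the shared core.

For the measured compounds named here, no step between two measured compounds carries this change, so the expectation rests on the direction already seen: growth at this part of the core went with weaker inhibition from compound 1 to compound 2. A further, smaller step in the same direction seems most likely, though one that may not exceed the scatter. The step of a 1.7-fold higher number from compound 2 to compound 3 (0.23 log units; within the scatter) is therefore expected to be modest and toward a higher number. Compound 3 is expected to give about 16 nM, with a plausible range from 5 nM to 50 nM.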

Compound 3, half-maximal inhibitory concentration: 9.8 nM
The estimate for compound 3 lay 1.6-fold (0.21 log units) above the measured number; the range from low to high includes it.
By their numbers in this assay, from the lowest: compound 1; then compounds 2 and 3 (each within the scatter of the next).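

In this assay, methyl in place of hydrogen on a saturated chain carbon bound to an aromatic carbon, which reads as methyl to ethyl on the shared core, gives a clean single-place comparison at this position (a 1.0-fold higher number from compound 2 to compound 3 (0.02 log units; within the scatter)). No earlier pair among the compounds shown isolated one change here, so this is the only direct reading of the position so far. It shows that, on this read-out, compound 2 and compound 3 cannot be told apart, and that going from methyl to ethyl at this place leaves no difference that repeated measurement could separate. Nothing available bears on why the two numbers coincide.

A longer chain at this place, such as propyl, or a group of another kind, such as an amine or a carboxylic acid, lies outside the compounds shown, so it remains open whether the match holds beyond ethyl. Also open, going by these compounds, is whether the same change would read alike on the core of compound 1, which carries no such chain.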